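The compounds below may be only part of what the source reports. "The series", "measured", "known", "first", "only" and "open" are said of these compounds alone.

Measured compounds:
- compound 1 `O=C1N/C(=N/c2csc(-c3ccc(Cl)cc3)c2)S/C1=C\c1ccccn1`, 21600 nM
- compound 2 `CN(C)c1ccc(/C=C2\S/C(=N\c3nc(-c4ccc(Cl)cc4)cs3)NC2=O)cc1`, 200 nM

In a functional assay on HCT-116 cells (Homo sapiens) for cytotoxicity, read by MTT assay, with a stated time of 72 h (on this read-out higher numbers stand for weaker inhibition and lower numbers for stronger inhibition), compound 2 gives the lowest of the two numbers; compound 1 gives a number that is higher by a margin well beyond the scatter. Going by the values given here, the two compounds differ in more than one place, so no single step is drawn between them.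

Compound 3 `O=C1N/C(=N/c2nc(-c3ccc(Cl)cc3)cs2)S/C1=C\c1ccc2ccccc2c1` is not yet measured. It is built from compound 2 by the change (naphthalen-2-yl in place of 4-(dimethylamino)phenyl on a double-bonded chain carbon bound to a double-bonded ring carbon). The change removes the only hydrogen-bond acceptor of the leaving group and adds a second carbocyclic aromatic ring.

Nothing in the measured pair isolates this position, so the direction rests on the structural change alone. The expectation is a loss of potency of moderate size, a 10-fold higher number from compound 2 to compound 3 (1.00 log units; beyond the scatter), in this assay. Compound 3 is estimated at 2000 nM, with a range from 400 nM to 10000 nM.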

Compound 3, half-maximal inhibitory concentration: 1200 nM
The estimate for compound 3 lay 1.7-fold (0.22 log units) above the measured number; low and high end bracket the measured number.
By their numbers in this assay, from the lowest: compound 2; then compound 3; then compound 1.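

In this assay, this position now has its first single-place reading: naphthalen-2-yl in place of 4-(dimethylamino)phenyl on a double-bonded chain carbon bound to a double-bonded ring carbon gives a 6.0-fold higher number from compound 2 to compound 3 (0.78 log units; beyond the scatter). The number therefore responds to the group at this place with the rest of the structure held constant, and the step runs toward weaker inhibition for this exchange. No supporting data on the origin of this step are available.

The step swaps one ring carrying a hydrogen-bond acceptor for two rings carrying none, so the loss of the dimethylamino nitrogen and the gain of the second ring cannot be told apart. As far as these compounds go, a plain phenyl or a 4-methoxyphenyl at this place would separate the two, and how far other amines, such as a morpholine, hold the number remains open.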